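Lengthening the amine-bearing group on a shared core

This account rests on a few compounds, and the source may have more. Where it says the series, first, only, none or still open, it means among the compounds named here.

Among the compounds with values here, in a functional assay (Pituitary gland cell) with Rattus norvegicus as the target (on this read-out lower numbers stand for an effect already at smaller amounts and higher numbers for an effect only at larger amounts of compound), compound 1 (`CC(C)(CC(=O)N[C@@H]1CCc2ccccc2N(Cc2ccc(-c3ccccc3-c3nn[nH]n3)cc2)C1=O)NC[C@H](O)CO`) gives 10 nM and compound 2 (`CC(C)(N)C(=O)N[C@@H]1CCc2ccccc2N(Cc2ccc(-c3ccccc3-c3nn[nH]n3)cc2)C1=O`) gives 30 nM, so compound 2 holds the higher of the only two numbers so far. Compound 3 (`CCCNC(C)(C)CC(=O)N[C@@H]1CCc2ccccc2N(Cc2ccc(-c3ccccc3-c3nn[nH]n3)cc2)C1=O`) has not yet been measured. It keeps the shared core and differs from compound 2 at one place, on a carbonyl carbon: 2-methyl-2-(propylamino)propyl in place of 1-amino-1-methylethyl on a carbonyl carbon.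

Within the data shown here, one measured step bears on this change: a 3.0-fold higher number from compound 1 to compound 2 (0.48 log units; beyond the scatter). This is a modest step, and it is beyond the scatter. It involves the same place, where compound 1 carries 2-((2,3-dihydroxypropyl)amino)-2-methylpropyl. Among the measured compounds shown here, that group resembles the one entering compound 3, which has propylamino instead of the dihydroxypropyl amino. Read backwards, the step links the larger group to the lower number. For the measured compounds named here, no measured compound shows how much of that gap would survive with a plain propyl group, so the expectation stays loose. A modest step toward a lower number is expected in this assay, estimated as a 2.3-fold lower number from compound 2 to compound 3 (0.36 log units; beyond the scatter). For compound 3 the estimated value is 13 nM, with an expected range of 4 nM to 40 nM.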

Compound 3, concentration for half-maximal effect: 50 nM
Beside the measured number, compound 3's estimate is 3.8-fold (0.59 log units) below it; the measured number lies above the stated range.
By their numbers in this assay, from the lowest: compound 1; then compounds 2 and 3 (each within the scatter of the next).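

In this assay the change from 1-amino-1-methylethyl to 2-methyl-2-(propylamino)propyl on a carbonyl carbon gives a 1.7-fold higher number from compound 2 to compound 3 (0.22 log units; within the scatter) so the larger group with a plain propyl on its amine does not by itself bring the lower number that the first step seemed to link to size. What separates the compounds lies further out on the chain: ethyl in place of 1,2-dihydroxyethyl on a saturated chain carbon bound to an amine nitrogen gives a 5.0-fold higher number from compound 1 to compound 3 (0.70 log units; beyond the scatter) and this leaves compound 1, with its 2,3-dihydroxypropyl group, apart from the other two compounds. Nothing measured here gives a reason for that gap.

Open, from the compounds shown here alone, is where a 2-hydroxyethyl group or a carboxylic acid on the same amine nitrogen would fall relative to the dihydroxypropyl and propyl groups. Also open, going by these compounds, is what the longer chain does when it ends in a free primary amine, as compound 3 lengthens the chain and adds the propyl group in a single change.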